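Bromo in place of propyl on the anilino ring

This account rests on a few compounds, and the source may have more. Where it says the series, first, only, none or still open, it means among the compounds named here.

The study follows a series of anilino-substituted derivatives sharing one core and measured in a functional assay on ECa-109 cells for inhibition, with ECa-109 cell line (Homo sapiens) as the target, read by sulforhodamine B assay; a higher number here means a weaker inhibitor, a lower number a stronger inhibitor. Compound 1, `CCCc1ccc(NC2=CC(=O)c3c(nc4n3[C@H]3OC[C@@H](O)[C@H]3OC4)C2=O)cc1`, carries a propyl group on the anilino ring. In this assay compound 1 gives only a limit of the assay, > 4000 nM, and no number. A close relative, compound 2, `CCc1ccc(NC2=CC(=O)c3nc4n(c3C2=O)[C@H]2OC[C@@H](O)[C@H]2OC4)cc1`, bears an ethyl group in the same position; in this assay compound 2 gives 3080 nM. Both values sit at the weak end of the range covered by the assay, with the limit of > 4000 nM in this assay, at which 1 of the 2 values shown sits, marking the limit that holds for compound 1.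

The next compound, compound 3, `O=C1C(Nc2ccc(Br)cc2)=CC(=O)c2c1nc1n2[C@H]2OC[C@@H](O)[C@H]2OC1`, is not yet measured. It differs from compound 1 in one place: bromo in place of propyl on an aromatic carbon. No measured step of this kind exists among the compounds shown, so the expectation rests on compound 1 and compound 2 alone. Given that compound 1 gives > 4000 nM and compound 2 gives 3080 nM, the step from compound 1 to compound 3 is expected to be small, an at least 1.0-fold lower number from compound 1 to compound 3 (0.02 log units; that floor lies within the scatter), probably none beyond the usual scatter. Compound 3 is therefore estimated at 3800 nM, with a likely range from 1500 nM to 9000 nM.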

Compound 3, half-maximal inhibitory concentration: 1980 nM
Beside the measured number, compound 3's estimate is 1.9-fold (0.28 log units) above it, within the range that was stated.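

In this assay, compound 3 with its 4-bromophenyl group gives a measured number, whereas the 4-propylphenyl group of compound 1 gives only a limit of the assay, so this position on the anilino ring can carry bromo and still return a value. The change amounts to an at least 2.0-fold lower number from compound 1 to compound 3 (0.30 log units; that floor lies within the scatter), and this figure is a floor rather than a size, so the data do not say how far apart the two compounds really lie. The step can be read no more closely than this because compound 1 is held at a limit: the limit of > 4000 nM in this assay, at which 1 of the 3 values shown sits.

The compounds shown leave open whether chloro, fluoro, methoxy or an amine at the same place on the ring would give a lower number than bromo does in compound 3. They also leave open what a plain hydrogen at this place would give, a comparison that would separate what the bromo adds from what the loss of the propyl chain alone does.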